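The source may hold more compounds than are shown below. What is called first, only, known or untested is meant among the compounds shown, and "the series" means these compounds.

Compound 1 `O=S(=O)(NCCCN1CCc2ccccc2C1)c1ccc2ccccc2c1` gives 80 nM in an assay on HEK293 cells for displacement of a labelled ligand from 5-hydroxytryptamine receptor 7 (Homo sapiens), read by scintillation counting, with a stated time of 1 h; a higher number here means a weaker inhibitor, a lower number a stronger inhibitor.
Compound 2 `O=S(=O)(NCCCN1CCc2ccccc2C1)c1ccccc1` gives 270 nM in this assay.
Compound 3 `O=S(=O)(NCCCCN1CCc2ccccc2C1)c1ccc2ccccc2c1` gives 64 nM in this assay.

Among these three, compound 2 gives the highest number. Compound 1 gives a lower number, and compound 3 a lower number still, and both of those differences lie beyond the usual scatter of this assay. Compound 4 `NCCN(CCCN1CCc2ccccc2C1)S(=O)(=O)c1ccccc1` differs from compound 2 by 2-aminoethyl in place of hydrogen on a sulfonamide nitrogen. Among the measured compounds shown here, no measured pair shows this change, so its effect has no precedent here. The expected step of a 1.4-fold lower number from compound 2 to compound 4 (0.13 log units; within the scatter) is small, leaning toward a lower number but possibly staying within the scatter. Compound 4 is therefore estimated at 200 nM, with a range from 60 nM to 700 nM.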

Compound 4, inhibition constant: 267 nM
Estimate against measurement, compound 4: 1.3-fold (0.13 log units) below; the measured number falls inside the stated range.
By their numbers in this assay, from the lowest: compounds 3 and 1 (each within the scatter of the next); then compounds 4 and 2 (each within the scatter of the next).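

In this assay, 2-aminoethyl in place of hydrogen on a sulfonamide nitrogen gives a 1.0-fold lower number from compound 2 to compound 4 (0.00 log units; within the scatter). Among the compounds shown here, this is the first reading at this position, and it shows that the sulfonamide nitrogen can carry 2-aminoethyl instead of its hydrogen with the two numbers lying within the scatter of each other. Nothing measured here accounts for this result.

The compounds shown leave open whether a methyl group, a longer aminoalkyl chain or a carboxylic acid would be accepted at this nitrogen. They also leave open whether 2-aminoethyl would give a similar result on the core of compound 1.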